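Swapping methoxy for chloro on the pendant phenyl

The compounds below may be only part of what the source reports. "The series", "measured", "known", "first", "only" and "open" are said of these compounds alone.

Three compounds share one core. Compound 1 `O=S(=O)(c1cc(F)cc(F)c1)c1cnc2c(F)cccc2c1-c1cccc(Cl)c1` gives 0.64 mL/min in an ADME assay on microsomes from liver (Homo sapiens) for metabolic stability, tested at 2.5 uM; a lower number here means slower removal, a higher number faster removal of the compound. Compound 2 `COc1ccc(S(=O)(=O)c2cnc3c(F)cccc3c2-c2cccc(Cl)c2)cc1` gives 2.75 mL/min there, and a 4.3-fold higher number from compound 1 to compound 2 (0.63 log units; beyond the scatter). Compound 3 `COc1cccc(-c2c(S(=O)(=O)c3ccc(F)cc3)cnc3c(F)cccc23)c1` gives 2.23 mL/min, the second highest of the three numbers: it sits within the scatter of compound 2 and beyond the scatter above compound 1.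

Compound 4 `O=S(=O)(c1ccc(F)cc1)c1cnc2c(F)cccc2c1-c1cccc(Cl)c1` has not yet been measured. It differs from compound 3 in one place: chloro in place of methoxy on an aromatic carbon. Within the data shown here, no measured step changes this same position. Among the measured compounds shown here, the only measured step, from compound 1 to compound 2, concerns the ring on the sulfonyl sulfur, where a methoxy entered alongside a higher number; here a methoxy leaves, so a lower number is the natural expectation, although that step is only an indirect guide. Compound 4 also shares its 3-chlorophenyl with compound 1, whose number is the lowest of the three, while keeping the 4-fluorophenyl on the sulfonyl sulfur of compound 3.

Compound 4 is therefore expected to give 1.1 mL/min in this assay, between 0.5 mL/min and 2.6 mL/min, a step of a 2.0-fold lower number from compound 3 to compound 4 (0.31 log units; beyond the scatter) that is estimated to fall just beyond the scatter downward.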

Compound 4, intrinsic clearance in a liver preparation (reported as CLH), per the amount of preparation that the assay uses: 1.21 mL/min
The estimate for compound 4 lay 1.1-fold (0.04 log units) below the measured number, within the range that was stated.
By their numbers in this assay, from the lowest: compounds 1, 4, 3 and 2 (each within the scatter of the next, the first and the last beyond it).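

In this assay, among these compounds, the first measured change at this position, 3-methoxyphenyl to 3-chlorophenyl, gives a 1.8-fold lower number from compound 3 to compound 4 (0.27 log units; within the scatter) and so does not stand clear of the usual scatter on this core. With the 3-chlorophenyl kept in place, the ring on the sulfonyl sulfur can now be compared twice: fluoro in place of methoxy gives a 2.3-fold lower number from compound 2 to compound 4 (0.36 log units; beyond the scatter) and stands clear of the scatter. By contrast, 4-fluorophenyl in place of 3,5-difluorophenyl gives a 1.9-fold higher number from compound 1 to compound 4 (0.28 log units; within the scatter) and does not.

The compounds shown leave open how the number would move with an amine or a carboxylic acid at this position on the pendant phenyl, and whether the methoxy-to-chloro step would read the same with another ring on the sulfonyl sulfur. Nothing given here accounts for any of these steps.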